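Clearance across three compounds, and a methoxy question

The source may hold more compounds than are shown below. What is called first, only, known or untested is meant among the compounds shown, and "the series" means these compounds.

Values so far in an in vitro ADME assay on microsomes from liver (Homo sapiens) for pharmacokinetics, read by LC-MS, with a stated time of 10 min, tested at 1 uM; a higher number here means faster removal of the compound, a lower number slower removal
Compound 1 `CN1C[C@H](C(=O)Nc2ccc(C#N)cc2)[C@@H](c2ccc(/C=C/C(=O)Nc3ccccc3N)cc2)C1` gives 1 mL/min/kg
Compound 2 `CC(C)c1ccc(NC(=O)[C@H]2CN(C)C[C@@H]2c2ccc(/C=C/C(=O)Nc3ccccc3N)cc2)cc1` gives 10 mL/min/kg
Compound 3 `CN1C[C@H](C(=O)Nc2ccc(C(F)(F)F)cc2)[C@@H](c2ccc(/C=C/C(=O)Nc3ccccc3N)cc2)C1` gives 6 mL/min/kg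

Compound 2 stands well clear of one neighbour (a 10-fold higher number from compound 1 to compound 2 (1.00 log units; beyond the scatter)) but not of the other (a 1.7-fold lower number from compound 2 to compound 3 (0.22 log units; within the scatter)). Compound 4 `COc1cccc(NC(=O)[C@H]2CN(C)C[C@@H]2c2ccc(/C=C/C(=O)Nc3ccccc3N)cc2)c1` carries 3-methoxyphenyl in place of 4-isopropylphenyl on an amide-type nitrogen. Among the measured compounds shown here, no measured compound has a methoxy group, so the measured steps give only a rough size. Swapping one group on an aromatic carbon can matter (a 6.0-fold higher number from compound 1 to compound 3 (0.78 log units; beyond the scatter)), yet need not. A small move in this assay, perhaps slightly downward but not beyond the scatter, is expected (a 1.4-fold lower number from compound 2 to compound 4 (0.15 log units; within the scatter)). The estimate for compound 4 is 7 mL/min/kg (expected range 2.5 mL/min/kg to 18 mL/min/kg).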

Compound 4, clearance: 14 mL/min/kg
Compound 4: the middle estimate sits 2.0-fold (0.30 log units) below what was measured; measured number inside the range.
By their numbers in this assay, from the lowest: compound 1; then compounds 3, 2 and 4 (each within the scatter of the next, the first and the last beyond it).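

In this assay, a methoxy group on this aromatic ring, the first among these compounds, leaves the number close to that of the isopropyl compound: a 1.4-fold higher number from compound 2 to compound 4 (0.15 log units; within the scatter). The other two steps are clearer, a 2.3-fold higher number from compound 3 to compound 4 (0.37 log units; beyond the scatter) and a 14-fold higher number from compound 1 to compound 4 (1.15 log units; beyond the scatter), so the 4-cyanophenyl of compound 1 remains apart from all three other groups. Nothing available explains these differences.

As far as these compounds go, since 3-methoxyphenyl and 4-isopropylphenyl differ in both the group and where it sits, the effect of each remains open. So does the outcome with an amine or a carboxylic acid on this ring.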